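The source may report more compounds than this note shows. Statements on the series, on what has been measured and on what is new or still open speak of the compounds shown alone.

Compound 1 `C=C1C(=O)O[C@]2(C)CC[C@@H]1C[C@H](O)[C@@]1(C)CC[C@H](O1)[C@](C)(O)CC[C@H]2OC(C)=O`: in a functional assay on HeLa cells (Homo sapiens) for cytotoxicity, read by MTT assay (a lower number here means that less compound is needed, a higher number that more compound is needed for the effect), compound 1 gives < 20 ug/mL, which is a limit of the assay rather than a number.
Compound 2 `C=C1C(=O)O[C@]2(C)CC[C@@H]1C[C@H](O)[C@@]1(C)CC[C@H](O1)[C@](C)(O)CC[C@H]2O`: in this assay compound 2 gives < 20 ug/mL, again a limit rather than a number.
Compound 3 `C=C1C(=O)O[C@]2(C)CC[C@@H]1C[C@H](O)[C@@]1(C)CC[C@H](O1)C(=C)CC[C@H]2OC(C)=O`: in this assay compound 3 gives < 20 ug/mL, once more a limit rather than a number.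

Compound 3 therefore stands exactly where every measured value stands, at the limit of < 20 ug/mL in this assay, at which 3 of the 3 values shown sit; nothing in the numbers places it above or below compound 1 or compound 2. Among the compounds with values here, the one measured step that touches the same kind of change is a step that the two limits leave unreadable from compound 1 to compound 2, hydrogen in place of acetyl on an oxygen on a saturated carbon, which is the reverse of the change examined here, and its size cannot be read.

Compound 4 `C=C1C(=O)O[C@]2(C)CC[C@@H]1C[C@H](OC(C)=O)[C@@]1(C)CC[C@H](O1)C(=C)CC[C@H]2OC(C)=O` differs from compound 3 by acetyl in place of hydrogen on an oxygen on a saturated carbon. Within the data shown here, with the one related step unreadable and all three measured values sitting at the limit, no direction of change beyond the scatter can be expected for this assay. Compound 4 is expected to give 10 ug/mL, within a range from 3 ug/mL to 30 ug/mL. The step that the limit leaves unreadable from compound 3 to compound 4 is expected to remain within the scatter, and most probably only a limit will again be reported.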

Compound 4, concentration for half-maximal effect: < 20 ug/mL
Compound 4: no number, only a limit (the forecaster's own chance of this, stated with the estimate: 70%); the middle value does not contradict the limit.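

Compound 3 and compound 4 both give only a limit rather than a number, so the step from hydroxy to acetoxy between them cannot be read: the limit of < 20 ug/mL in this assay, at which 4 of the 4 values shown sit. Left open is whether this or any other difference among compound 1, compound 2, compound 3 and compound 4 changes the concentration needed in this assay.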